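A few compounds are considered here, and "the series" means these few. Any claim that something is new, unique, unknown or untested is made for them only; others in the source may bear on it.

Compound 2 `O=C(C1CCC2(CCC2)CC1)N1CC(c2nc(-c3cccc(Cl)c3)no2)C1`: 1100 nM
Compound 1 `O=C(c1ccccc1F)N1CC[C@H]1c1nc(-c2cccc(F)c2)no1`: > 10000 nM
Compound 3 `Cc1ccc(S(=O)(=O)N2CC(c3nc(-c4cccc(Cl)c4)no3)C2)cc1`: > 10000 nM

Within the data shown here, in an assay on HEK293 cells for positive allosteric modulation of metabotropic glutamate receptor 5 (Homo sapiens), read by FLIPR (on this read-out higher numbers stand for an effect only at larger amounts of compound and lower numbers for an effect already at smaller amounts), compound 2 gives 1100 nM, the only measured number among the three. Compound 1 reaches only the limit of the assay, at > 10000 nM. Compound 3 likewise reaches only the limit, at > 10000 nM. Compound 2 therefore stands alone with a number, set against (the limit of > 10000 nM in this assay, at which 2 of the 3 values shown sit). Compound 4 `CC1CN(C(=O)N2CC(c3nc(-c4cccc(Cl)c4)no3)C2)CC(C)O1` differs from compound 2 by a group of 8 heavy atoms (6 carbon, 1 nitrogen, 1 oxygen; one six-membered non-aromatic ring with 2 hetero atoms) in place of a group of 9 heavy atoms (9 carbon; one four-membered non-aromatic ring of carbon only, one six-membered non-aromatic ring of carbon only), on a carbonyl carbon. Among the measured compounds shown here, no step between two measured compounds that differ in a single place is available, so the size of this change has no measured counterpart here. The estimated step, a 3.6-fold higher number from compound 2 to compound 4 (0.56 log units; beyond the scatter), is expected to be upward and beyond the usual scatter. For compound 4 the estimate is 4000 nM, within 1500 nM to 10000 nM, with a fair chance that only a limit is reported.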

Compound 4, half-maximal effective concentration: > 10000 nM
Compound 4: no number, only a limit; the forecaster's own chance of this, stated with the estimate: 40%; middle value at least 2.5-fold (0.39 log units) away from the limit.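

Among these compounds, the exchange at this carbonyl carbon gives the only single-place comparison here, and 2,6-dimethylmorpholin-4-yl in place of the carbon-only group brings an at least 9.0-fold higher number from compound 2 to compound 4 (0.95 log units; beyond the scatter). Because compound 4 gives only a limit, the full size of this step stays unknown, and compound 2 remains the only compound with a number: the limit of > 10000 nM in this assay, at which 3 of the 4 values shown sit.

The compounds shown leave open whether a piperidine or a plain cyclohexyl group on this carbonyl carbon would give a number. They also leave open whether the ring oxygen or the two methyl groups of compound 4 account for the step.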